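The source may hold more compounds than are shown below. What is called first, only, known or untested is meant among the compounds shown, and "the series" means these compounds.

Notes on the series

Measured so far in a functional assay on A549 cells (Homo sapiens) for inhibition, read by MTT assay, with a stated time of 72 h; on this read-out lower numbers stand for stronger inhibition and higher numbers for weaker inhibition:
compound 1, `O=C1Nc2ccccc2/C1=N/NC(=S)N1CCN(c2ccccc2)CC1`, gives 18600 nM
compound 2, `O=C1Nc2cc(Cl)ccc2/C1=N/NC(=S)N1CCN(c2ccccc2)CC1`, gives 27700 nM
compound 3, `O=C1Nc2ccccc2/C1=N/NC(=S)Nc1ccccc1`, gives only a limit, > 100000 nM

Compounds 1 and 2 differ by one change, (chloro in place of hydrogen on an aromatic carbon). This change is measured as a 1.5-fold higher number from compound 1 to compound 2 (0.17 log units; within the scatter), so the two values of this assay cannot be told apart. For compound 3 this assay reports a limit and no number; this is the limit of > 100000 nM in this assay, at which 1 of the 3 values shown sits. The difference between the core of compound 1 and the core of compound 3 is not broken down here.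

Compound 4, `O=C1Nc2ccc(Cl)cc2/C1=N/NC(=S)Nc1ccccc1`, is not yet measured. It differs from compound 3 by chloro in place of hydrogen on an aromatic carbon, the same change as that from compound 1 to compound 2, at a place described in the same words. Since the measured step of a 1.5-fold higher number from compound 1 to compound 2 (0.17 log units; within the scatter) sits within the scatter, no shift is expected from the same change here, and compound 4 is expected to stand at a step that the limit leaves unreadable from compound 3 to compound 4. Compound 4 is therefore estimated at 150000 nM, with a range of 60000 nM to 400000 nM, and this assay is expected to return only a limit again rather than a number.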

Compound 4, half-maximal inhibitory concentration: 33100 nM
Estimate against measurement, compound 4: 4.5-fold (0.66 log units) above; measured number below the stated range.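

In this assay the change of hydrogen to chloro gives an at least 3.0-fold lower number from compound 3 to compound 4 (0.48 log units; beyond the scatter), and this step does not match the one measured on the other core: the same change on two cores in this assay, a 1.5-fold higher number (0.17 log units; within the scatter) from compound 1 to compound 2 and an at least 3.0-fold lower number (0.48 log units; beyond the scatter) from compound 3 to compound 4, at least 4.4-fold (0.65 log units) apart, beyond the scatter of two such steps

Compound 3 gives only a limit and no number: the limit of > 100000 nM in this assay, at which 1 of the 4 values shown sits.

The change therefore does not carry over unaltered from the core of compound 1 to the core of compound 3, but the full size of the step on the second core stays unknown, and two pairs neither give a reason for the difference nor predict the step on any further core.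

The compounds shown leave open whether another group on the same aromatic carbon, such as fluoro, methoxy or an amine, would also differ in its effect between these two cores. Also open, from the compounds shown here alone, is how a carboxylic acid or a longer chain on the terminal phenyl ring would stand on either core.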